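The source may hold more compounds than are shown below. What is called first, only, known or untested is meant among the compounds shown, and "the series" means these compounds.

Compound 1 (`Cc1cc(C)n(-c2nc(-c3ccccc3)c(C)c(=O)[nH]2)n1`) gave no number ("not determined" (no result reported))
Compound 2 (`Cc1cc(C)n(-c2nc(C(F)(F)F)cc(=O)[nH]2)n1`) gave one number (0.006)

In an ADME assay on a cell-free system (plasma, Homo sapiens) for protein binding, read by LC-MS, using ultracentrifugation, with stated times of 1 h and 4 h, at 37 degrees C, tested at 5 uM (on this read-out lower numbers stand for a smaller free fraction and higher numbers for a larger free fraction), compound 2 gives 0.006 as the only number shown, while compound 1 has no result reported, so compound 2 cannot yet be ranked against any other measured compound. Compound 3 (`Cc1cc(NC2CCOCC2)n(-c2nc(C(F)(F)F)cc(=O)[nH]2)n1`) is still to be measured. It keeps the core of compound 2 but carries (oxan-4-yl)amino in place of methyl on an aromatic carbon of a five-membered aromatic ring with 2 nitrogen. Among the measured compounds shown here, no two measured compounds differ in one place, so no measured step guides the size of this one, and the expectation rests on the structural change alone. In this assay a modest rise toward a larger free fraction is expected, probably a little beyond the usual scatter, though a result within that scatter would not surprise. The estimated change is a 3.3-fold higher number from compound 2 to compound 3 (0.52 log units; beyond the scatter) and it remains a judgement from a single number. For compound 3 the expected unbound fraction is 0.02 and the estimated range runs from 0.007 to 0.05 in this account.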

Compound 3, unbound fraction in the Homo sapiens assay: 0.014
Estimate against measurement, compound 3: 1.4-fold (0.15 log units) above; low and high end bracket the measured number.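

Among the compounds shown here, in the Homo sapiens assay, putting (oxan-4-yl)amino in place of methyl on an aromatic carbon of the five-membered ring gives a 2.3-fold higher number from compound 2 to compound 3 (0.37 log units; beyond the scatter), the first measured step in this set and the first reading of how the unbound fraction responds to a change at this position. The much larger group, which brings a non-aromatic six-membered ring and a hydrogen-bond donor, moves the number up, yet compound 3, at 0.014, still has only a small free fraction. In a physicochemical assay for solubility, read by HPLC, measured as kinetic solubility, with a stated time of 20 h, at pH 7.4, tested at 200 uM (a higher number here means a more soluble compound, a lower number a less soluble compound), compound 2 gives 200000 nM and compound 3 gives 50000 nM, so the same replacement moves the number the other way: the measured solubility of compound 2, 200000 nM, and of compound 3, 50000 nM, a 4.0-fold lower number (0.60 log units; beyond the scatter)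

As far as these compounds go, with a single step, it remains open which part of the (oxan-4-yl)amino group goes with the higher unbound fraction, the linking nitrogen or the ring, and a plain amine or a carboxylic acid at this position would help to separate the two. From the compounds shown here alone, it also remains open whether the step would carry over to the core of compound 1, or whether a larger free fraction can be had at this position without the lower solubility seen for compound 3.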